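Removing one methyl: from compound 2 to compound 3

The source may hold more compounds than are shown below. What is called first, only, known or untested is meant among the compounds shown, and "the series" means these compounds.

Compound 1 `Cc1c(CN(C)C)c2ccccc2n1Cc1ccc(C(=O)NO)cc1` gives > 5000 nM (a limit)
Compound 2 `Cc1c(CN(C)C)c2ccccc2n1S(=O)(=O)c1cccc(/C=C/C(=O)NO)c1` gives 1690 nM (a number)

For the measured compounds named here, in a functional assay on PC-3 cells (Homo sapiens) for antiproliferative activity, read by sulforhodamine B assay, with a stated time of 48 h (on this read-out higher numbers stand for weaker inhibition of growth and lower numbers for stronger inhibition of growth), compound 2 gives 1690 nM and this is the only number so far. Compound 1 stands at > 5000 nM which is a limit and not a number. Compound 3 `CN(C)Cc1cn(S(=O)(=O)c2cccc(/C=C/C(=O)NO)c2)c2ccccc12` is still unmeasured: relative to compound 2 it has hydrogen in place of methyl on an aromatic carbon and is otherwise the same. Going by the values given here, no measured step covers this change, so a modest move is expected, a 1.5-fold lower number from compound 2 to compound 3 (0.19 log units; within the scatter) toward stronger inhibition of growth. The estimated value for compound 3 is 1100 nM with an expected range from 350 nM to 3500 nM on this read-out.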

Compound 3, concentration for 50% growth inhibition: 1030 nM
Estimate against measurement, compound 3: 1.1-fold (0.03 log units) above; the range from low to high includes it.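

For the compounds shown here, the first measured step at this position shows that in this assay, hydrogen in place of methyl on this aromatic carbon gives a 1.6-fold lower number from compound 2 to compound 3 (0.22 log units; within the scatter). The methyl is therefore not needed for the growth inhibition seen in this series, and the shared core keeps its effect without it. Nothing shown gives a cause for this step.

On these data alone, how an ethyl, a chlorine or a methoxy group on this carbon would read stays open. As far as these compounds go, it is also open whether removing the methyl would have a similar effect in compound 1, the benzyl-linked compound.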